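The compounds below may be only part of what the source reports. "The series", "measured", "known", "first", "only" and "open" are said of these compounds alone.

Going by the values given here, in an assay on HEK293 cells for displacement of a labelled ligand from Translocator protein (Homo sapiens), read by scintillation counting, with a stated time of 90 min (on this read-out higher numbers stand for weaker inhibition and lower numbers for stronger inhibition), compound 2 `CC(=O)N(Cc1ccc(OC(C)C)cc1)c1cc(C)cc(C)c1` gives 3150 nM, and the one other number measured so far, that of compound 1 `COc1ccc(CN(C(C)=O)c2cc(C)cc(C)c2)cc1` at 2790 nM, lies within the scatter of it, as the step of a 1.1-fold higher number from compound 1 to compound 2 (0.05 log units; within the scatter) shows. Compound 3 `CC(=O)N(Cc1ccc(OCc2ccccc2)cc1)c1cc(C)cc(C)c1` differs from compound 2 by benzyl in place of isopropyl on an oxygen on an aromatic ring. Among the compounds with values here, the only measured step that bears on this change is a 1.1-fold higher number from compound 1 to compound 2 (0.05 log units; within the scatter), in which enlarging the group on this oxygen produced no movement beyond the scatter. No benzyl group on this oxygen has been measured, so the expectation rests on that single step alone. Compound 3 is therefore expected to show a 1.1-fold lower number from compound 2 to compound 3 (0.02 log units; within the scatter), a step inside the scatter. The estimated value of compound 3 is 3000 nM, within 1000 nM to 9000 nM.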

Compound 3, inhibition constant: 738 nM
The estimate for compound 3 lay 4.1-fold (0.61 log units) above the measured number; measured number outside the range, below it.
By their numbers in this assay, from the lowest: compound 3; then compounds 1 and 2 (each within the scatter of the next).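

At this oxygen on an aromatic ring, the group does change the number in this assay: benzyl in place of isopropyl gives a 4.3-fold lower number from compound 2 to compound 3 (0.63 log units; beyond the scatter), whereas the earlier swap of methyl for isopropyl stayed within the scatter. Against the smallest group the change gives a 3.8-fold lower number from compound 1 to compound 3 (0.58 log units; beyond the scatter), so among these three compounds only the benzyl group, the one group with a ring, stands apart. Nothing at hand accounts for this shift. From the compounds shown here alone, it remains open whether the aromatic ring matters, which a cyclohexylmethyl group on this oxygen would address. Going by these compounds, a longer chain such as phenethyl, or a pyridylmethyl group, also remains open.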